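A few compounds are considered here, and "the series" means these few. Any claim that something is new, unique, unknown or untested is made for them only; others in the source may bear on it.

Working notes on the series, read in a physicochemical assay for solubility, in phosphate buffer, at pH 7.4; a higher number here means a more soluble compound, a lower number a less soluble compound. Compound 1 (`COc1cc(F)ccc1-c1ccnc2[nH]c(C3CCN(CC(=O)N(C)C)CC3)cc12`) gives 38000 nM, a measured number. Compound 2 (`CN(C)C(=O)CN1CCC(c2cc3c(-c4ccc(=O)n(C5CCC5)c4)ccnc3[nH]2)CC1`) gives > 1000000 nM, which is a limit of the assay and not a number. Of the two compounds, compound 2 therefore stands at the top of the reported range, and compound 1 lies lower.

Compound 3 (`CN(C)C(=O)CN1CCC(c2cc3c(-c4ccc(=O)n(C)c4)ccnc3[nH]2)CC1`) keeps the rest of compound 2 and differs in one place: methyl in place of cyclobutyl on an aromatic nitrogen. In words, this is methyl in place of cyclobutyl on an aromatic nitrogen. Going by the values given here, no measured pair isolates this change, so there is no direct precedent for its size.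

The expectation rests only on compound 2, which sits at the limit of > 1000000 nM in this assay, at which 1 of the 2 values shown sits. No step beyond the usual scatter is expected in this assay, and a second report at the limit is quite possible. The expected change is an at least 1.1-fold lower number from compound 2 to compound 3 (0.04 log units; that floor lies within the scatter). For compound 3, the estimated value is 900000 nM. The expected range for compound 3 runs from 300000 nM to 1000000 nM.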

Compound 3, solubility: > 1000000 nM
Compound 3: only a limit was reported; the forecaster's own chance of this, stated with the estimate: 60%; at least 1.1-fold (0.04 log units) between middle value and limit.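

In this assay compound 3 gives > 1000000 nM, which is a limit of the assay and not a number. With compound 2 also reported at a limit, the step for methyl in place of cyclobutyl on an aromatic nitrogen cannot be read, and the only finding at this position is that both groups give a report at the limit: the limit of > 1000000 nM in this assay, at which 2 of the 3 values shown sit.

The result does add a readable step at a different place, the group on an aromatic carbon of the shared core, where a group with a six-membered aromatic ring with 1 hetero atom stands in place of a group with a six-membered aromatic ring of carbon only: an at least 26-fold higher number from compound 1 to compound 3 (1.42 log units; beyond the scatter).

On these data alone, how far compound 2 and compound 3 lie past the limit stays unknown, and the two groups on the aromatic nitrogen cannot be ranked in this assay. Also open, as far as these compounds go, is whether a different group on that nitrogen, such as a longer chain like n-octyl or a chain ending in a phenyl ring, would give a measured number rather than another limit.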